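Adding Ethyl to the End of a Diene Chain

The source may hold more compounds than are shown below. What is called first, only, known or untested is meant among the compounds shown, and "the series" means these compounds.

Compound 1 `CO/C=C(\C=C\c1ccc(OC)c(O)c1)c1cc(OC)c(OC)c(OC)c1` gives 5630 nM
Compound 2 `CC=C(/C=C/c1ccc(OC)c(N)c1)c1cc(OC)c(OC)c(OC)c1` gives 217 nM
Compound 3 `C=C(/C(C)=C/c1ccc(OC)c(O)c1)c1cc(OC)c(OC)c(OC)c1` gives 60 nM

All three numbers come from a functional assay on HeLa cells (Homo sapiens) for antiproliferative activity, read by MTT assay, with a stated time of 48 h; on this read-out lower numbers stand for stronger inhibition and higher numbers for weaker inhibition. Compound 3 at 60 nM has the lowest of the three, and its gaps to both other compounds lie beyond the usual scatter of repeated measurements. Compound 4 `CCC=C(/C(C)=C/c1ccc(OC)c(O)c1)c1cc(OC)c(OC)c(OC)c1` has not yet been measured. The change from compound 3 to compound 4 is ethyl in place of hydrogen on a double-bonded chain carbon bound to a double-bonded chain carbon, which puts ethyl in place of hydrogen on a double-bonded chain carbon bound to a double-bonded chain carbon.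

Among the measured compounds shown here, no measured pair isolates this change, so the guidance is indirect. Compound 2 also lacks a hydrogen at that carbon and reads 217 nM in this assay, and compound 1 likewise reads 5630 nM there. Both also differ from compound 3 elsewhere, which makes this a weak hint. Even so, a move toward a higher number, beyond the scatter, is expected. The expected size is an estimated 4.2-fold higher number from compound 3 to compound 4 (0.62 log units; beyond the scatter) in this assay here. For compound 4 the estimated value is 250 nM, with an expected range from 70 nM to 900 nM as its ends.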

Compound 4, half-maximal inhibitory concentration: 3130 nM
Estimate against measurement, compound 4: 13-fold (1.10 log units) below, and the stated range ends below it.
By their numbers in this assay, from the lowest: compound 3; then compound 2; then compounds 4 and 1 (each within the scatter of the next).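

Among the compounds shown here, compounds 3 and 4 differ in one place only, so this pair gives a direct reading of the position that the earlier compounds could only hint at, since each of them also differed elsewhere. In this assay, ethyl in place of hydrogen on a double-bonded chain carbon bound to a double-bonded chain carbon brings a large loss of antiproliferative inhibition (a 52-fold higher number from compound 3 to compound 4 (1.72 log units; beyond the scatter)), so this carbon is far from indifferent to what it carries, at least on this core. Nothing measured here explains the loss, so the result records what happens at this position but not the reason for it.

The compounds shown have only hydrogen and ethyl to compare at this carbon, so they leave open whether a single methyl would already bring much of the loss, or whether a longer chain such as propyl would make it greater still. They also leave open whether a hydroxyl or an amine at the same carbon would behave like ethyl or like hydrogen, and whether the same swap would cost as much on a core carrying different groups elsewhere.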